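Swapping the Amide Cap: Expected Cytotoxicity of Compound 3

The source may report more compounds than this note shows. Statements on the series, on what has been measured and on what is new or still open speak of the compounds shown alone.

Three compounds built on one shared core differ only in the group that caps the amide-type nitrogen. Compound 1 `CC(C)(C)OC(=O)Nc1ncc(C(Oc2ccc(F)c(Cl)c2)c2ccc(Cl)cc2)s1` carries a tert-butyl carbamate there. In an ADME assay on HepG2 2.2.15 cells (Homo sapiens) for cytotoxicity (on this read-out higher numbers stand for lower toxicity in this test and lower numbers for higher toxicity in this test), compound 1 gives > 50000 nM, which is a limit of the test rather than a measured number. Compound 2 `O=C(Nc1ncc(C(Oc2ccc3cc(Br)ccc3c2)c2ccc(Cl)cc2)s1)c1cccs1` carries a (thiophen-2-yl)carbonyl on that nitrogen. In this assay compound 2 is recorded as "not toxic" (no number reported), again with no number. For the measured compounds named here, both known results thus sit at the non-toxic end of the scale, the one for compound 1 at the limit of > 50000 nM in this assay, at which 1 of the 2 values shown sits, and the one for compound 2 in the same region.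

Compound 3 `N#Cc1cccc(C(=O)Nc2ncc(C(Oc3ccc4cc(Br)ccc4c3)c3ccc(Cl)cc3)s2)c1` differs from compound 2 by 3-cyanophenyl in place of thiophen-2-yl on a carbonyl carbon. Going by the values given here, no step between two measured compounds is available to guide this change, so only the position of compound 2 can serve. Since compound 1 and compound 2 both stay at the non-toxic end, compound 3 is expected to do the same, with no shift beyond the usual scatter. In this assay compound 3 is estimated at 50000 nM, with a range from 20000 nM to 100000 nM, and it will most likely again be reported as a limit.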

Compound 3, half-maximal cytotoxic concentration: > 50000 nM
Compound 3 ended at the assay's limit; the forecaster's own chance of this, stated with the estimate: 80%; the middle value sits exactly at the limit.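

In this assay compound 3 gives > 50000 nM, which is a limit of the test and not a measured number. For the compounds shown here, compound 2 has no number at all, so no step from compound 2 to compound 3 can be read. The compounds shown leave open whether changing the cap on the nitrogen alters cytotoxicity at all.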